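This account rests on a few compounds, and the source may have more. Where it says the series, first, only, none or still open, it means among the compounds named here.

Series notes, read in a functional assay on MDA-MB-231 cells (Homo sapiens) for inhibition, read by CCK-8 assay, with a stated time of 48 h; a lower number here means a stronger inhibitor of growth, a higher number a weaker inhibitor of growth. Compound 1 `CN1CCN(c2ccc(Nc3ncc(Cl)c(Nc4ccccc4)n3)nc2)CC1` gives 37400 nM. Compound 2 `CN1CCN(c2ccc(Nc3ncc(Cl)c(NCc4ccc(F)cc4)n3)nc2)CC1` stands at > 100000 nM, which is a limit of the assay and not a number. Among the measured compounds shown here, compound 3 `COc1ccc(CNc2nc(Nc3ccc(N4CCN(C)CC4)cn3)ncc2Cl)cc1` gives 14900 nM, the lowest number so far.

Compound 4 `CN1CCN(c2ccc(Nc3ncc(Cl)c(NCc4ccco4)n3)nc2)CC1` has furan-2-yl in place of 4-methoxyphenyl on a saturated chain carbon bound to a nitrogen on an aromatic ring. For the measured compounds named here, no measured step exchanges this ring directly, so the nearest evidence comes from changes at the same nitrogen substituent. Replacing phenyl gives a 2.5-fold lower number from compound 1 to compound 3 (0.40 log units; beyond the scatter) with 4-methoxybenzyl, but an at least 2.6-fold higher number from compound 1 to compound 2 (0.42 log units; beyond the scatter) with 4-fluorobenzyl. Methoxy in place of fluoro gives an at least 6.7-fold lower number from compound 2 to compound 3 (0.82 log units; beyond the scatter).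

Compound 4 also loses the methoxy group, and compound 2, which lacks it too, shows the larger number in an at least 6.7-fold lower number from compound 2 to compound 3 (0.82 log units; beyond the scatter). A modest rise is therefore expected, beyond the scatter but uncertain in size. The expected step is a 2.7-fold higher number from compound 3 to compound 4 (0.43 log units; beyond the scatter). For compound 4 the estimated value is 40000 nM, with an expected range of 13000 nM to 100000 nM.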

Compound 4, concentration for 50% growth inhibition: 11000 nM
Compound 4: middle estimate off by 3.6-fold (0.56 log units), on the high side, outside the stated range (below it).
By their numbers in this assay, from the lowest: compounds 4 and 3 (each within the scatter of the next); then compound 1. At a limit, above all of these: compound 2.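

In this assay, furan-2-yl in place of 4-methoxyphenyl on the saturated chain carbon gives a 1.4-fold lower number from compound 3 to compound 4 (0.13 log units; within the scatter), so the methoxy group and the six-membered aromatic ring are not both required to reach this level. Among the compounds shown here, the same (furan-2-yl)methyl group gives a 3.4-fold lower number from compound 1 to compound 4 (0.53 log units; beyond the scatter) against phenyl on the nitrogen and an at least 9.0-fold lower number from compound 2 to compound 4 (0.95 log units; beyond the scatter) against 4-fluorobenzyl, which leaves compound 2 as the one benzyl-type compound that goes against a gain over compound 1. The value of compound 2 is a limit of the assay and not a number: the limit of > 100000 nM in this assay, at which 1 of the 4 values shown sits.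

From the compounds shown here alone, whether a thiophen-2-yl ring or a saturated tetrahydrofuran-2-yl ring would hold this level remains open. Also open, going by these compounds, is how a longer chain between the nitrogen and furan-2-yl would read in this assay.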